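A Piperidine Amide Tail and Vero Cell Toxicity

The source may hold more compounds than are shown below. What is called first, only, known or untested is meant among the compounds shown, and "the series" means these compounds.

Compound 2 `CCC(=O)Nc1ccc(-c2nc3ccccc3[nH]2)cc1` is measured in an ADME assay on Vero cells (Chlorocebus sabaeus) for cytotoxicity (on this read-out lower numbers stand for higher toxicity in this test and higher numbers for lower toxicity in this test), where compound 2 reaches only the limit > 100000 nM, which is a boundary of the test and not a number. Compound 1 `CC(=O)Nc1ccc(-c2nc3ccccc3[nH]2)cc1` also gives a limit in this assay, > 100000 nM. Within the data shown here, the one measured step, a step that the two limits leave unreadable from compound 1 to compound 2, cannot be read, since both of its ends sit at the limit of > 100000 nM in this assay, at which 2 of the 2 values shown sit.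

Compound 3 `O=C(CN1CCCCC1)Nc1ccc(-c2nc3ccccc3[nH]2)cc1` differs from compound 2 by piperidin-1-yl in place of methyl on a saturated chain carbon bound to a carbonyl carbon. Among the measured compounds shown here, no measured step covers a change of this kind; the only step available, from compound 1 to compound 2, leaves its size hidden behind the limit. With both measured compounds sitting at the limit, the expected step is a number no higher from compound 2 to compound 3 (the limit leaves the size open), which is to say none beyond the scatter. Compound 3 is estimated at 100000 nM, with a range from 30000 nM to 300000 nM.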

Compound 3, half-maximal cytotoxic concentration: > 100000 nM
Compound 3: a limit, no number; the forecaster's own chance of this, stated with the estimate: 70%; the middle value sits exactly at the limit.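

Among these compounds, compound 3 also gives only a limit and not a number, so no step among compound 1, compound 2 and compound 3 can be read in this assay: the limit of > 100000 nM in this assay, at which 3 of the 3 values shown sit.

The compounds shown leave open whether any group at this place on the saturated chain carbon would give a readable value.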